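The compounds below may be only part of what the source reports. "The series", "measured", "known", "first", "only" and "open" are said of these compounds alone.

Measured compounds:
compound 1 `ClCc1ccccc1Cn1cnc2c(Cl)nc(Cl)nc21`: > 100000 nM in a functional assay on Hs-578T cells (Homo sapiens) for cytotoxicity, read by sulforhodamine B assay, with a stated time of 48 h (a higher number here means that more compound is tolerated, a lower number that less compound is tolerated), a limit of the assay.
compound 2 `ClCc1ccc(Cn2cnc3nc(Cl)nc(Cl)c32)cc1`: > 100000 nM in this assay, a limit of the assay.
compound 3 `ClCc1ccccc1Cn1cnc2nc(Cl)nc(Cl)c21`: > 100000 nM in this assay, a limit of the assay.

Compound 2 stands only as a limit in this assay; no number is known for it. Among the compounds with values here, the other two compounds stand at the same point, as the limit of > 100000 nM in this assay, at which 3 of the 3 values shown sit, shows, so no measured step gives a size or a direction for this assay. Compound 4 `ClCc1ccc(Cn2cnc3ncnc(Cl)c32)cc1` is not yet measured. It differs from compound 2 by hydrogen in place of chloro on an aromatic carbon. With every value in the series sitting at the limit, the step from compound 2 to compound 4 is expected to be a step that the limit leaves unreadable from compound 2 to compound 4, no change beyond the scatter, and the most likely outcome is once more only a limit rather than a number. For compound 4 the estimate in this assay is 150000 nM, with a range from 50000 nM to 500000 nM.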

Compound 4, concentration lethal to 50% of the cells: > 100000 nM
Compound 4: no number, only a limit; the forecaster's own chance of this, stated with the estimate: 80%; the middle value does not contradict the limit.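

The step from compound 2 to compound 4 cannot be read, since both stand only as limits: the limit of > 100000 nM in this assay, at which 4 of the 4 values shown sit.

The compounds shown leave open the size and direction of hydrogen in place of chloro in this assay, and whether any compound of this series gives a number there.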